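Replacing 1,2-dihydroxyethyl with 1-carboxy-1-methylethyl in compound 2

The compounds below may be only part of what the source reports. "The series", "measured", "known", "first", "only" and "open" are said of these compounds alone.

Compound 1 `Cc1ccc(Cn2c(=O)n(CC(C)(C)C(=O)O)c(=O)[nH]/c2=N\c2ccc(OC(C)C)c(Cl)c2)cc1` (0.01)
Compound 2 `CC(C)Oc1ccc(/N=c2\[nH]c(=O)n(C[C@@H](O)CO)c(=O)n2Cc2ccc(Cl)cc2)cc1Cl` (0.001)
Compound 3 `C[C@@H](Cn1c(=O)[nH]/c(=N\c2ccc(Oc3cncc(F)c3)cc2)n(Cc2ccc(Cl)cc2)c1=O)C(=O)O` (0.02)

In an ADME assay on the whole organism (plasma, Rattus norvegicus) for protein binding, using cassette dosing, at a dose of 1 mg/kg (a higher number here means a larger unbound share of the compound, a lower number a smaller unbound share), compound 2 stands lowest of the three (0.001), and the numbers for compound 1 and compound 3 both lie higher, beyond the scatter. Compound 4 `CC(C)Oc1ccc(/N=c2\[nH]c(=O)n(CC(C)(C)C(=O)O)c(=O)n2Cc2ccc(Cl)cc2)cc1Cl` has not yet been measured. It departs from compound 2 by one change 1-carboxy-1-methylethyl in place of 1,2-dihydroxyethyl on a saturated chain carbon bound to an aromatic nitrogen with 1-carboxy-1-methylethyl in place of 1,2-dihydroxyethyl on a saturated chain carbon bound to an aromatic nitrogen. For the measured compounds named here, no step between two measured compounds isolates this change, so any expectation rests on their values alone. Compound 1 carries the same 2-carboxy-2-methylpropyl chain and gives (0.01), while compound 3 also carries a carboxy group and gives (0.02). An upward step beyond the scatter is therefore expected (an 8.0-fold higher number from compound 2 to compound 4 (0.90 log units; beyond the scatter)). For compound 4 the estimated unbound fraction is (0.008), with an expected range from (0.003) to (0.02).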

Compound 4, unbound fraction: 0.003
Compound 4: middle estimate off by 2.7-fold (0.43 log units), on the high side; the range from low to high includes it.
By their numbers in this assay, from the lowest: compound 2; then compound 4; then compounds 1 and 3 (each within the scatter of the next).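

In this assay, replacing 2,3-dihydroxypropyl with 2-carboxy-2-methylpropyl on a saturated chain carbon bound to an aromatic nitrogen now stands as an isolated change, and it gives a 3.0-fold higher number from compound 2 to compound 4 (0.48 log units; beyond the scatter), a rise beyond the scatter. The chain is not the only place that moves this read-out, since with 2-carboxy-2-methylpropyl held constant, chloro in place of methyl on an aromatic carbon gives a 3.3-fold lower number from compound 1 to compound 4 (0.52 log units; beyond the scatter), also beyond the scatter. Nothing shown here accounts for either step.

The compounds leave open whether the carboxylic acid or the pair of methyl groups on the chain carries the rise, which a simple unbranched carboxyethyl chain or a methyl ester could separate. They also leave open how other aromatic groups, such as fluoro or methoxy, would compare with chloro and methyl.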